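This account rests on a few compounds, and the source may have more. Where it says the series, first, only, none or still open, it means among the compounds named here.

Of the compounds shown here, two have been measured in a functional assay on SK-MEL-5 cells (Homo sapiens) for inhibition; on this read-out higher numbers stand for weaker inhibition of growth and lower numbers for stronger inhibition of growth. Compound 1, with the structure `COc1cc(/C=C/C(=O)c2cccc(-n3cc(-c4ccc(Cl)cc4)[nH]c3=O)c2)ccc1O`, gives 1800 nM. Compound 2, with the structure `COc1cc(/C=C/C(=O)c2cccc(-n3cc(-c4ccccc4)[nH]c3=O)c2)cc(OC)c1OC`, gives 1400 nM. The gap between these two numbers is smaller than the usual scatter of repeated measurements, so the two cannot be told apart on this read-out, and compound 2 simply serves as the starting point for the next step. Compound 3, with the structure `COc1ccc(-c2cn(-c3cccc(C(=O)/C=C/c4cc(OC)c(OC)c(OC)c4)c3)c(=O)[nH]2)cc1`, has not yet been measured. It differs from compound 2 in one place: methoxy in place of hydrogen on an aromatic carbon. Among the compounds with values here, no measured pair in this set shows what a methoxy group added in this way does, so nothing here tells whether the number will move up or down. The estimate for compound 3 is therefore kept close to compound 2 because compound 2 gives 1400 nM in this assay. The expected step is a 1.1-fold lower number from compound 2 to compound 3 (0.03 log units; within the scatter), which lies within the scatter. Compound 3 is expected to give 1300 nM, with a likely range from 500 nM to 3500 nM.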

Compound 3, concentration for 50% growth inhibition: 2030 nM
Compound 3: the middle estimate sits 1.6-fold (0.19 log units) below what was measured; low and high end bracket the measured number.
By their numbers in this assay, from the lowest: compounds 2, 1 and 3 (each within the scatter of the next).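

In this assay, within the data shown here, the change from phenyl to 4-methoxyphenyl gives a 1.5-fold higher number from compound 2 to compound 3 (0.16 log units; within the scatter), the first direct reading of what happens at this position, and it does not separate the two compounds. On this read-out, then, a methoxy group can sit on this six-membered aromatic ring, para to a large group, without any change that can be told from ordinary repeat-to-repeat variation, even though it adds 2 heavy atoms and a hydrogen-bond acceptor. No supporting measurement is available that would help interpret this result.

On these data alone, it remains open whether a different group at the same position, such as an amine, a carboxylic acid or a longer chain like butoxy, would produce a step that rises clearly above the scatter. This is also a single step on one background, so whether methoxy would read the same way on a compound with a different substitution pattern elsewhere on the shared core cannot be said from these compounds.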